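Indole hydrazide series: ring-nitrogen methylation and cytotoxicity

The compounds below may be only part of what the source reports. "The series", "measured", "known", "first", "only" and "open" are said of these compounds alone.

Measured compounds:
Compound 1, `COc1ccc2c(c1)c(/C=N\NC(=O)c1cn(C)c3ccccc13)cn2Cc1ccc(Cl)cc1`, 93000 nM in a functional assay on DU-145 cells (Homo sapiens) for cytotoxicity; on this read-out lower numbers stand for stronger inhibition and higher numbers for weaker inhibition
Compound 2, `COc1ccc2c(c1)c(/C=N\NC(=O)c1c[nH]c3ccccc13)cn2Cc1ccc(Cl)cc1`, 50000 nM in this assay
Compound 3, `O=C(N/N=C\c1cn(Cc2ccc(Cl)cc2)c2cc(F)ccc12)c1c[nH]c2ccccc12`, 18600 nM in this assay

Compound 3 gives the lowest of the three numbers; its steps to compound 2 and to compound 1 both lie beyond the usual scatter. The difference between the core of compound 3 and the core of compound 2 is not broken down here.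

Compound 2 and compound 1 differ by methyl in place of hydrogen on an aromatic nitrogen. This change gave a 1.9-fold higher number from compound 2 to compound 1 (0.27 log units; within the scatter), a step that stays within the scatter, so the two values cannot be ordered.

Compound 4, `Cn1cc(C(=O)N/N=C\c2cn(Cc3ccc(Cl)cc3)c3cc(F)ccc23)c2ccccc21`, has not yet been measured in this assay. It differs from compound 3 by methyl in place of hydrogen on an aromatic nitrogen, the same change that separates compound 2 from compound 1, made at the same place. On the core of compound 2 the change moved the number only within the scatter. For the measured compounds named here, the step from compound 3 to compound 4 is therefore expected to be of similar size, a 1.9-fold higher number from compound 3 to compound 4 (0.27 log units; within the scatter), resting on the single measured pair. Compound 4 is expected to give about 35000 nM in this assay, with a plausible range from 15000 nM to 80000 nM.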

Compound 4, half-maximal inhibitory concentration: 84200 nM
Beside the measured number, compound 4's estimate is 2.4-fold (0.38 log units) below it, and the stated range ends below it.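

On the core of compound 3, methyl in place of hydrogen on an aromatic nitrogen gave a 4.5-fold higher number from compound 3 to compound 4 (0.66 log units; beyond the scatter) in this assay. Set beside the step on the core of compound 2, the two results cannot be told apart, although only the step on the core of compound 3 stands clear of the scatter by itself: the same change on two cores in this assay, a 1.9-fold higher number (0.27 log units; within the scatter) from compound 2 to compound 1 and a 4.5-fold higher number (0.66 log units; beyond the scatter) from compound 3 to compound 4, 2.4-fold (0.39 log units) apart, within the scatter of two such steps. For these two cores, the change can be carried across as one that leaves the number unchanged within the scatter or raises it, but two pairs do not show that this holds on other cores in the series or fix the size of the step on any core.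

The compounds shown carry only hydrogen or methyl on this aromatic nitrogen, so the effect of an ethyl group, a longer chain or a chain ending in an amine at that place remains open. Also open, on these data alone, is whether the step seen in this assay would carry over to other read-outs, and how much of the gap in values from compound 3 to compound 2 belongs to each difference in their cores.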